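Amide variation on a shared naphthol–triazolylthio core

This account rests on a few compounds, and the source may have more. Where it says the series, first, only, none or still open, it means among the compounds named here.

Compound 1 `O=C(/C=C/c1ccccc1)Nc1cc(Sc2ncn[nH]2)c(O)c2ccccc12` and compound 2 `O=C(Nc1cc(Sc2ncn[nH]2)c(O)c2ccccc12)c1ccc(Cl)cc1` share one core and differ only at the carbonyl carbon. In an assay on isolated protein for inhibition of RAC-alpha serine/threonine-protein kinase (Homo sapiens), read by fluorescence, with a stated time of 30 min, tested at 10 uM (a higher number here means more inhibition at the concentration tested (going by the name of the read-out), a lower number less inhibition), compound 1 gives 26.2%, and in this assay compound 2 gives 50.1%. Going by the values given here, the one step measured so far, a number 23.9 percentage points higher from compound 1 to compound 2 (beyond the scatter), puts compound 2 at the highest of the two numbers seen, with compound 1 as its only neighbour.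

Compound 3 `Cc1cccc(C(=O)Nc2cc(Sc3ncn[nH]3)c(O)c3ccccc23)c1` is not yet measured in this assay. It differs from compound 2 by 3-methylphenyl in place of 4-chlorophenyl on a carbonyl carbon. Among the compounds with values here, no measured step bears directly on this exchange of one aryl group for another on the carbonyl carbon; the step from compound 1 to compound 2 concerns a 2-phenylethenyl against an aryl and says nothing about which aryl. With nothing in the numbers to argue for a change beyond the scatter, the expected step is a number 8.1 percentage points lower from compound 2 to compound 3 (within the scatter), that is, little movement from compound 2 and a wide range either way. Compound 3 is therefore estimated at 42% in this assay, between 20% and 62%.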

Compound 3, a percentage reported as inhibition, at one concentration (the size of the read-out at that concentration, not a potency): 20.2%
Compound 3: middle estimate off by 21.8 percentage points, on the high side; measured number inside the range.
By their numbers in this assay, from the lowest: compounds 3 and 1 (each within the scatter of the next); then compound 2.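

In this assay, the carbonyl carbon proves sensitive to which aryl group it carries, not only to whether it carries an aryl group: 3-methylphenyl in place of 4-chlorophenyl, with the heavy-atom count unchanged, gives a number 29.9 percentage points lower from compound 2 to compound 3 (beyond the scatter). The other new step, a number 6 percentage points lower from compound 1 to compound 3 (within the scatter), leaves 3-methylphenyl and 2-phenylethenyl unseparated here, so an aryl group on the carbonyl carbon does not by itself match the number of compound 2, whose steps to both neighbours lie beyond the scatter. The two aryl groups have the same counts of ring atoms, hydrogen-bond donors and acceptors and the same lack of net charge, and no measurement on these compounds accounts for the gap between them.

The step from 4-chlorophenyl to 3-methylphenyl changes both the substituent and the number in the group name, and only a pair such as 4-methylphenyl and 3-chlorophenyl on the same carbonyl carbon could tell which of the two goes with the step. Also open, as far as these compounds go, is how this carbonyl carbon would read with an aminophenyl group, a phenyl group bearing a carboxylic acid, or a longer alkyl chain in place of the aryl group.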